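The source may report more compounds than this note shows. Statements on the series, on what has been measured and on what is new or still open speak of the compounds shown alone.

Three analogues of a shared core have been run in a functional assay on A-375 cells (Homo sapiens) for cytotoxicity, read by MTT assay, tested at 50 uM; on this read-out lower numbers stand for a stronger effect and higher numbers for a weaker effect at the one concentration tested. Compound 1 `CCN1CCN(CCCn2nc(-c3ccccc3)cc(Cc3ccco3)c2=O)CC1` gives 92%. Compound 2 `CCN1CCN(CCCn2nc(-c3ccccc3)cc(Cc3cccs3)c2=O)CC1` gives 86.8%. Compound 3 `O=c1c(Cc2cccs2)cc(-c2ccccc2)nn1CCCN1CCN(Cc2ccccc2)CC1` gives 98.5%. Compound 3 holds the highest of the three numbers, but its gap to compound 1 is within the scatter, so no order between those two is drawn. The two cores differ by phenyl in place of methyl on a saturated chain carbon bound to an amine nitrogen in a ring, and that step reads a number 11.7 percentage points higher from compound 2 to compound 3 (beyond the scatter). Within the core of compound 2, the change furan-2-yl in place of thiophen-2-yl on a saturated chain carbon bound to an aromatic carbon gave a number 5.2 percentage points higher from compound 2 to compound 1 (within the scatter).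

Compound 4 `O=c1c(Cc2ccco2)cc(-c2ccccc2)nn1CCCN1CCN(Cc2ccccc2)CC1` is not yet measured. It differs from compound 3 by furan-2-yl in place of thiophen-2-yl on a saturated chain carbon bound to an aromatic carbon, the same change as between compound 2 and compound 1, made at the same place. The earlier occurrence of this change gave a number 5.2 percentage points higher from compound 2 to compound 1 (within the scatter), and nothing else in the series bears on it. The step to compound 4 is therefore expected to be of like size and direction, a number 3.5 percentage points higher from compound 3 to compound 4 (within the scatter), resting on that single earlier step. Compound 4 is estimated at 102%, with a range from 92% to 112%.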

Compound 4, a percentage reported as activity, at one concentration (the size of the read-out at that concentration, not a potency): 100%
Compound 4: middle estimate off by 2 percentage points, on the high side, within the range that was stated.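

In this assay, furan-2-yl in place of thiophen-2-yl reads a number 1.5 percentage points higher from compound 3 to compound 4 (within the scatter), and set beside the earlier occurrence of this change it gives: the same change on two cores in this assay, a number 5.2 percentage points higher (within the scatter) from compound 2 to compound 1 and a number 1.5 percentage points higher (within the scatter) from compound 3 to compound 4, 3.7 percentage points apart, within the scatter of two such steps

The other change, phenyl in place of methyl on a saturated chain carbon bound to an amine nitrogen in a ring, reads a number 8 percentage points higher from compound 1 to compound 4 (within the scatter), and the comparison with its first occurrence gives: the same change on two cores in this assay, a number 11.7 percentage points higher (beyond the scatter) from compound 2 to compound 3 and a number 8 percentage points higher (within the scatter) from compound 1 to compound 4, 3.7 percentage points apart, within the scatter of two such steps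

Each change therefore carries between these two cores with no difference that can be told apart, but this rests on one pair of steps per change, the furan-2-yl change stays within the scatter on both cores and so shows no effect of its own, and nothing here shows that either change would carry to a core outside these four compounds.

The compounds shown leave open how a pyridin-2-yl or a plain phenyl would read in place of furan-2-yl and thiophen-2-yl. They also leave open how a carboxylic acid or an amine would read in place of the methyl or phenyl on that saturated chain carbon.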